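A few compounds are considered here, and "the series" means these few. Any claim that something is new, unique, unknown or untested is made for them only; others in the source may bear on it.

Measured so far in a functional assay on DU-145 cells (Homo sapiens) for inhibition, read by trypan blue exclusion, with a stated time of 96 h; on this read-out higher numbers stand for weaker inhibition of growth and lower numbers for stronger inhibition of growth
- compound 1 `Cc1ccc(S/C(=C/c2c[nH]c3ccccc23)C(=O)c2ccc(Br)cc2)cc1` gives 10000 nM
- compound 2 `COc1ccc(/C=C(/Sc2ccc(C)cc2)C(=O)c2ccc(Br)cc2)cc1` gives 50000 nM
- compound 3 `Cc1ccc(S/C(=C/c2ccc(Cl)cc2)C(=O)c2ccc(Br)cc2)cc1` gives 10000 nM

Compound 1 shares its number with compound 3, and the two sit together at the low end of this small set, with a 5.0-fold higher number from compound 1 to compound 2 (0.70 log units; beyond the scatter) as the gap upward. Compound 4 `Cc1ccc(S/C(=C/c2c[nH]c3ccc(Br)cc23)C(=O)c2ccc(Br)cc2)cc1` keeps the core of compound 1 and carries one change, (bromo in place of hydrogen on an aromatic carbon), that is, bromo in place of hydrogen on an aromatic carbon. Among the compounds with values here, no measured step makes this exact change. The nearest guides are loose: a 5.0-fold lower number from compound 2 to compound 3 (0.70 log units; beyond the scatter) when chloro replaces methoxy on an aromatic carbon, and no change at the digits printed from compound 1 to compound 3 (within the scatter) when 4-chlorophenyl replaces 1H-indol-3-yl. A small move toward a lower number is therefore expected, though perhaps none beyond the scatter. The expected step in this assay is a 1.7-fold lower number from compound 1 to compound 4 (0.22 log units; within the scatter), a modest one at most. For compound 4 the estimate is 6000 nM, with an expected range from 2000 nM to 20000 nM.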

Compound 4, concentration for 50% growth inhibition: 1000 nM
The estimate for compound 4 lay 6.0-fold (0.78 log units) above the measured number; measured number outside the range, below it.
By their numbers in this assay, from the lowest: compound 4; then compounds 1 and 3 (each within the scatter of the next); then compound 2.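

In this assay, adding one bromo to an aromatic carbon of the six-membered ring in the fused system gives a 10-fold lower number from compound 1 to compound 4 (1.00 log units; beyond the scatter). The earlier steps shown here only exchanged the whole group on the double-bonded chain carbon, whereas this one shows that a single added atom on that ring can shift the number beyond the scatter. Nothing available here explains the size of this step.

On these data alone, whether fluoro, an amine or a carboxylic acid at this carbon would act like bromo stays open. So does whether bromo on another carbon of this ring would give a similar step.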